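This account rests on a few compounds, and the source may have more. Where it says the series, first, only, none or still open, it means among the compounds named here.

The measured compounds:
Compound 1, `CC(C)C[C@H](N)c1ccccc1N1CCN(C(=O)[C@H](C)Cc2ccc(Cl)cc2F)CC1`: in an assay on HEK293 cells for displacement of a labelled ligand from Melanocortin receptor 4 (Homo sapiens) (on this read-out higher numbers stand for weaker inhibition and lower numbers for stronger inhibition), compound 1 gives 67 nM.
Compound 2, `Cc1ccc(N2CCN(C(=O)[C@H](C)Cc3ccc(Cl)cc3F)CC2)c([C@@H](N)CC(C)C)c1`: in this assay compound 2 gives 20 nM.

Going by the values given here, compound 1 stands at the higher of the two numbers; its only neighbour is compound 2, reached by a 3.4-fold lower number from compound 1 to compound 2 (0.53 log units; beyond the scatter), a methyl in place of hydrogen on an aromatic carbon of the shared core. Compound 3, `CC(C)C[C@H](N)c1ccccc1N1CCN(C(=O)[C@H](C)Cc2ccc(Cl)cc2Cl)CC1`, differs from compound 1 in another part of the molecule: chloro in place of fluoro on an aromatic carbon, so that the 4-chloro-2-fluorobenzyl group becomes a 2,4-dichlorobenzyl group. Among the compounds with values here, no measured pair touches this halogen, and the step from compound 1 to compound 2 concerns a different ring, so it gives no guide to the direction or size of the change. With nothing in the measured numbers speaking for a gain or a loss, the expected step for compound 3 is a 1.1-fold lower number from compound 1 to compound 3 (0.05 log units; within the scatter), within the scatter. Compound 3 is therefore estimated at 60 nM, with a range from 20 nM to 200 nM in this assay.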

Compound 3, inhibition constant: 16 nM
Compound 3: the middle estimate sits 3.8-fold (0.57 log units) above what was measured; measured number below the stated range.
By their numbers in this assay, from the lowest: compounds 3 and 2 (each within the scatter of the next); then compound 1.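

At the aromatic carbon ortho to a large group, the halogen turns out to matter in this assay: chloro in place of fluoro gives a 4.2-fold lower number from compound 1 to compound 3 (0.62 log units; beyond the scatter) and so moves the number beyond the scatter. The swap exchanges one heavy atom for one heavy atom and leaves the count of rings, hydrogen-bond donors and hydrogen-bond acceptors unchanged, yet it shows that the 4-chloro-2-fluorobenzyl group is a place where the number responds, which the earlier step could not show, since the methyl of compound 2 sits on a different ring. Nothing available explains why chloro gives the lower number here.

The compounds shown leave open how hydrogen, bromo, methyl or methoxy on this same carbon would compare with fluoro and chloro, so a single pair of halogens cannot yet be read as a trend. They also leave open whether the aromatic methyl of compound 2 and the 2,4-dichlorobenzyl group of compound 3, placed together in one molecule, would lower the number further.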